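Bulky amide substituents on a thiazolopyridine alkyne scaffold

The source may hold more compounds than are shown below. What is called first, only, known or untested is meant among the compounds shown, and "the series" means these compounds.

Measured compounds:
compound 1 `CCC(=O)N1CCc2nc(C#Cc3ccccc3)sc2C1` — 38 nM
compound 2 `CC1CCC(C(=O)N2CCc3nc(C#Cc4ccccc4)sc3C2)CC1` — > 10000 nM

Compound 1 `CCC(=O)N1CCc2nc(C#Cc3ccccc3)sc2C1` carries an ethyl group on the carbonyl carbon and, in an assay on HEK293 cells for negative allosteric modulation of metabotropic glutamate receptor 5 (Homo sapiens), read by FLIPR, with a stated time of 1 h (on this read-out higher numbers stand for weaker inhibition and lower numbers for stronger inhibition), compound 1 gives 38 nM. Compound 2 `CC1CCC(C(=O)N2CCc3nc(C#Cc4ccccc4)sc3C2)CC1` carries a 4-methylcyclohexyl group at the same place. In this assay compound 2 reaches only a limit, > 10000 nM. Among the compounds with values here, the single step between the measured compounds is an at least 260-fold higher number from compound 1 to compound 2 (2.42 log units; beyond the scatter); the value for compound 2 sits at the limit of > 10000 nM in this assay, at which 1 of the 2 values shown sits, so the true size of that step is not known beyond its lower bound.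

Compound 3 `O=C(CC1CCOCC1)N1CCc2nc(C#Cc3ccccc3)sc2C1` is the next compound, not yet measured. It differs from compound 2 in one place: (oxan-4-yl)methyl in place of 4-methylcyclohexyl on a carbonyl carbon. Both groups are of the same size in heavy atoms, and both are far larger than the ethyl of compound 1. Within the data shown here, the only step that bears on this change is the one from compound 1 to compound 2, which was large and points toward weak inhibition for bulky groups on the carbonyl carbon. The ring oxygen and the added methylene of compound 3 have no measured counterpart among the compounds shown, so their effect cannot be read from the data.

Compound 3 is therefore expected to remain weak in this assay, with a step of about an at least 1.6-fold lower number from compound 2 to compound 3 (0.22 log units; that floor lies within the scatter). The estimate for compound 3 is 6000 nM, within a range from 1000 nM to 30000 nM, with a fair chance that only a limit is reported again.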

Compound 3, half-maximal inhibitory concentration: > 10000 nM
Compound 3: only a limit was reported; the forecaster's own chance of this, stated with the estimate: 50%; at least 1.6-fold (0.22 log units) between middle value and limit.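

The result adds a second large step, an at least 260-fold higher number from compound 1 to compound 3 (2.42 log units; beyond the scatter), so the loss seen with 4-methylcyclohexyl on the carbonyl carbon is not confined to a group whose ring is of carbon only. In this assay, exchanging that ring for one with 1 hetero atom, and going from 0 hydrogen-bond acceptors to 1, still leaves compound 3 with only a limit and no measurable inhibition value. Because both compounds sit at a limit, the step from compound 2 to compound 3 cannot be read, and any difference between the two groups stays hidden: the limit of > 10000 nM in this assay, at which 2 of the 3 values shown sit.

Whether an isopropyl or a cyclopropyl group on the carbonyl carbon would keep the inhibition of compound 1 stays open, so the compounds shown do not tell how large a group can become before that inhibition is lost. As far as these compounds go, it is equally open whether an amine or a carboxylic acid in place of the ring oxygen of compound 3 would bring a value back within the range of the assay.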